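A few compounds are considered here, and "the series" means these few. Any claim that something is new, unique, unknown or untested is made for them only; others in the source may bear on it.

In an ADME assay on microsomes from liver (Canis lupus familiaris) for metabolic stability, with a stated time of 10 min (on this read-out lower numbers stand for a less stable compound and higher numbers for a more stable compound), compound 1 (`FC(F)(F)c1ccccc1-c1ccc2[nH]c(C3=NCC4(CCCCC4)N3)nc2c1`) shows 36% and compound 2 (`Fc1cc(-c2ccccc2C(F)(F)F)cc2nc(C3=NOC4(CCCCC4)C3)[nH]c12`) shows 87% while compound 3 (`FC(F)(F)c1ccccc1-c1cc(Cl)c2[nH]c(C3=NOC4(CCCCC4)C3)nc2c1`) stands highest of the three with 100% remaining. The next step leads to compound 4 (`FC(F)(F)c1ccccc1-c1cc(Br)c2[nH]c(C3=NOC4(CCCCC4)C3)nc2c1`) and changes a single atom (bromo in place of chloro on an aromatic carbon): bromo in place of chloro on an aromatic carbon. Going by the values given here, one measured step bears on it: chloro in place of fluoro gave a number 13 percentage points higher from compound 2 to compound 3 (beyond the scatter) and that is modest in size. Compound 3 at 100% has no room left to rise on this read-out. The estimated step is therefore small and within the scatter (a number 5 percentage points lower from compound 3 to compound 4 (within the scatter)) and, if anything, downward. In this assay the expected value for compound 4 is 95% with 82% as the lower end and 100% as the upper end.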

Compound 4, percent of the compound remaining: 74%
For compound 4 the middle estimate is 21 percentage points above the measured one; the whole stated range lies above it.
By their numbers in this assay, from the lowest: compound 1; then compound 4; then compound 2; then compound 3.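

On this aromatic carbon, ortho to a fused ring, swapping one halogen for another is not a neutral change in this assay, as bromo gives a number 26 percentage points lower from compound 3 to compound 4 (beyond the scatter). Bromo also falls short of fluoro, with a number 13 percentage points lower from compound 2 to compound 4 (beyond the scatter), so going from fluoro to chloro to bromo the number rises and then falls, with no steady trend across these three compounds. Nothing available here accounts for this drop. Still open, as far as these compounds go, is how a methyl or methoxy group on this carbon would compare with the three halogens, and whether the same halogen order would hold on the core of compound 1.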